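A Bromo Swap on the Carboxy Compound

This account rests on a few compounds, and the source may have more. Where it says the series, first, only, none or still open, it means among the compounds named here.

In a functional assay on K562 cells (Homo sapiens) for cytotoxicity, read by trypan blue exclusion, with a stated time of 96 h (on this read-out higher numbers stand for weaker inhibition and lower numbers for stronger inhibition), compound 1 (`COC(=O)C(Nc1cc(CS(=O)(=O)/C=C/c2c(OC)cc(OC)cc2OC)ccc1OC)c1ccc(F)cc1`) gives 800 nM, compound 2 (`COC(=O)C(Nc1cc(CS(=O)(=O)/C=C/c2c(OC)cc(OC)cc2OC)ccc1OC)c1ccc(Cl)cc1`) gives 200 nM and compound 3 (`COc1cc(OC)c(/C=C/S(=O)(=O)Cc2ccc(OC)c(NC(C(=O)O)c3ccc(F)cc3)c2)c(OC)c1`) gives 80 nM. Compound 3 thus holds the lowest number of the three, and its distance to each of the others lies beyond the scatter. Compound 4 (`COc1cc(OC)c(/C=C/S(=O)(=O)Cc2ccc(OC)c(NC(C(=O)O)c3ccc(Br)cc3)c2)c(OC)c1`) alters it in one place, with bromo in place of fluoro on an aromatic carbon, para to a large group: bromo in place of fluoro on an aromatic carbon. Within the data shown here, the nearest precedent is the exchange of fluoro for chloro, a 4.0-fold lower number from compound 1 to compound 2 (0.60 log units; beyond the scatter), a modest step beyond the scatter. That step was seen with the methoxycarbonyl group, whereas compound 3 carries the carboxy group, and the step of a 10-fold lower number from compound 1 to compound 3 (1.00 log units; beyond the scatter) shows that this exchange alone moves the number. Among the measured compounds shown here, no bromo compound has been measured yet, so only a modest step towards a lower number is expected in this assay. The expected step is a 2.7-fold lower number from compound 3 to compound 4 (0.43 log units; beyond the scatter). Compound 4 is estimated at 30 nM, with an expected range of 10 nM to 100 nM.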

Compound 4, half-maximal inhibitory concentration: 200 nM
For compound 4 the middle estimate is 6.7-fold (0.82 log units) below the measured one; measured number outside the range, above it.
By their numbers in this assay, from the lowest: compound 3; then compounds 2 and 4 (each within the scatter of the next); then compound 1.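

In this assay the exchange on this aromatic carbon does not keep one direction: chloro in place of fluoro gave a 4.0-fold lower number from compound 1 to compound 2 (0.60 log units; beyond the scatter) with the methoxycarbonyl group, while bromo in place of fluoro gives a 2.5-fold higher number from compound 3 to compound 4 (0.40 log units; beyond the scatter) with the carboxy group present. Read over the whole group on the nitrogen, there is no change at the digits printed from compound 2 to compound 4 (within the scatter) and a 4.0-fold lower number from compound 1 to compound 4 (0.60 log units; beyond the scatter) when the bromo carboxy compound is set against the two methoxycarbonyl compounds. Nothing available explains why the halogen exchange reads differently in the two settings.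

The compounds shown leave open where chloro would fall with the carboxy group, and whether bromo with the methoxycarbonyl group would follow the step seen with chloro. They also leave open how a methyl on the same aromatic carbon, or an amide in place of the carboxy group, would read.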